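Ethoxycarbonyl in place of methoxycarbonyl on a cytotoxic core

This account rests on a few compounds, and the source may have more. Where it says the series, first, only, none or still open, it means among the compounds named here.

Measured compounds:
compound 1, `COC(=O)/C1=C/[C@@H]2[C@@H](C(C)C)CC=C(C)[C@@H]2C[C@H](OC(=O)/C=C\c2cn(C)cn2)[C@]2(C)C=C[C@@]1(O)O2`, 0.09 ug/mL
compound 2, `COC(=O)/C1=C/[C@@H]2[C@@H](C(C)C)CC=C(C)[C@@H]2C[C@H](OC(=O)/C=C/c2cn(C)cn2)[C@]2(C)C=C[C@@]1(O)O2`, 0.017 ug/mL

In a functional assay on HeLa cells (Homo sapiens) for cytotoxicity (a lower number here means a stronger inhibitor, a higher number a weaker inhibitor), compound 1 gives 0.09 ug/mL, and in this assay compound 2 gives 0.017 ug/mL. The difference between them is a single drawn double-bond configuration, as the fact that compounds 1 and 2 differ only in the configuration as drawn records, and it carries a 5.3-fold lower number from compound 1 to compound 2 (0.72 log units; beyond the scatter). On the two numbers shown, compound 2 stands lowest, with compound 1 as its only neighbour at that distance.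

Compound 3, `CCOC(=O)/C1=C/[C@@H]2[C@@H](C(C)C)CC=C(C)[C@@H]2C[C@H](OC(=O)/C=C/c2cn(C)cn2)[C@]2(C)C=C[C@@]1(O)O2`, keeps everything in compound 2 except one point: methyl in place of hydrogen on a saturated chain carbon bound to an oxygen next to a carbonyl group. Read one bond further out, the methoxycarbonyl of compound 2 becomes the ethoxycarbonyl of compound 3. Among the measured compounds shown here, neither measured compound probes this part of the core; the only measured step concerns the double bond of the ester side chain, not the methoxycarbonyl, so it offers no guide to the size or direction of this change. With nothing pointing either way, the expected step of a 1.2-fold higher number from compound 2 to compound 3 (0.07 log units; within the scatter) is taken as one that stays within the scatter. Compound 3 is therefore estimated at 0.02 ug/mL in this assay, with a range from 0.006 ug/mL to 0.07 ug/mL that reflects the absence of any relevant measured step.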

Compound 3, half-maximal inhibitory concentration: 0.09 ug/mL
Compound 3: middle estimate off by 4.5-fold (0.65 log units), on the low side; the measured number lies above the stated range.
By their numbers in this assay, from the lowest: compound 2; then compounds 1 and 3 (each within the scatter of the next).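

At this position the shared core proves sensitive to a very small change: in this assay, going from methoxycarbonyl to ethoxycarbonyl gives a 5.3-fold higher number from compound 2 to compound 3 (0.72 log units; beyond the scatter), so the added methyl moves the result towards a weaker inhibitor. The earlier pair varied only the drawn configuration of the double bond in the ester side chain, whereas this step shows that a single methyl on a saturated chain carbon bound to an oxygen next to a carbonyl group also counts, with the rest of the structure held as in compound 2. Nothing given here explains why one added methyl has this effect, since the only available observation concerns the double-bond configuration and does not bear on the methoxycarbonyl to ethoxycarbonyl change.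

The compounds shown leave open whether a longer chain, such as propoxycarbonyl, would move the number further in the same direction, and whether a carboxylic acid or a primary amide could take the place of the ester at all. They also leave open whether the methyl addition would have a step of similar size when the double bond is drawn Z, as in compound 1.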